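The source may report more compounds than this note shows. Statements on the series, on what has been measured and on what is new or still open speak of the compounds shown alone.

Measured compounds:
compound 1, `O=[N+]([O-])c1cn2c(n1)OC[C@@H](OCc1ccc(-c3ccc(OC(F)(F)F)cc3)cc1Cl)C2`
compound 2, `O=[N+]([O-])c1cn2c(n1)OC[C@@H](OCc1ccc(-c3ccc(OC(F)(F)F)cc3)cc1C(F)(F)F)C2`

In an ADME assay on Vero cells (Chlorocebus sabaeus) for cytotoxicity, with a stated time of 72 h (a higher number here means a weaker inhibitor, a lower number a stronger inhibitor), compound 1 gives > 128000 nM, which is a limit of the assay and not a number. In this assay compound 2 gives > 128000 nM, likewise a limit. For the measured compounds named here, compound 2 therefore stands at the limit without a measured number, and the one further value shown is a limit as well. The step that the two limits leave unreadable from compound 1 to compound 2 cannot be read, because both of its values sit at the limit of > 128000 nM in this assay, at which 2 of the 2 values shown sit.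

Compound 3, `O=[N+]([O-])c1cn2c(n1)OC[C@@H](OCc1ccc(-c3ccc(OC(F)(F)F)cc3)cc1OC(F)(F)F)C2`, remains to be measured in this assay. Its difference from compound 2: trifluoromethoxy in place of trifluoromethyl on an aromatic carbon. Going by the values given here, only one measured step bears on a change at the same aromatic carbon, the step from compound 1 to compound 2, and its size is not readable because both ends sit at the limit of > 128000 nM in this assay, at which 2 of the 2 values shown sit. No direction can be drawn from it. Compound 3 is expected to sit at the same limit, with the step that the limit leaves unreadable from compound 2 to compound 3 expected to be none beyond the scatter. The estimate for compound 3 is 200000 nM, within 100000 nM to 500000 nM, most likely reported once more as a limit.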

Compound 3, half-maximal inhibitory concentration: > 128000 nM
Compound 3: no number, only a limit; the forecaster's own chance of this, stated with the estimate: 85%; the middle value does not contradict the limit.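

No new step can be read among compound 1, compound 2 and compound 3 in this assay, because all three stand at a limit of the assay and not at a number: the limit of > 128000 nM in this assay, at which 3 of the 3 values shown sit.

The compounds shown leave open whether chloro, trifluoromethyl and trifluoromethoxy on this aromatic carbon differ at all in this assay, and at what concentration any of the three would reach half-maximal inhibition.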